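Cyclohexylphenyl ether in place of isopropylphenyl ether

This account rests on a few compounds, and the source may have more. Where it says the series, first, only, none or still open, it means among the compounds named here.

The series shares a methyl glycoside core carrying two aryl ethers. Compound 1 `CO[C@H]1O[C@H](COc2ccc(OC3CCCCC3)cc2)[C@@H](O)[C@H](O)[C@H]1Oc1ccc(OC2CCCCC2)cc1` has the 4-cyclohexyloxyphenyl group at both positions; in a functional assay on A549 cells (Homo sapiens) for cytotoxicity, read by MTT assay, with a stated time of 48 h (on this read-out lower numbers stand for an effect already at smaller amounts and higher numbers for an effect only at larger amounts of compound), compound 1 gives 18000 nM. For the measured compounds named here, compound 2 `CO[C@H]1O[C@H](COc2ccccc2C(C)C)[C@@H](O)[C@H](O)[C@H]1Oc1ccc(OC2CCCCC2)cc1` carries a 2-isopropylphenyl group on the oxygen on the saturated chain carbon, and in this assay compound 2 gives 33000 nM, the highest of the two numbers so far, though compound 1 sits within the scatter of it. Compound 3 `CO[C@H]1O[C@H](COc2ccc(C3CCCCC3)cc2)[C@@H](O)[C@H](O)[C@H]1Oc1ccc(OC2CCCCC2)cc1` is the next member: 4-cyclohexylphenyl in place of 2-isopropylphenyl on an oxygen on a saturated carbon. Going by the values given here, no step between measured compounds exists yet, so the expected size of this change rests on compound 1, which carries a similar cyclohexyl-bearing aryl group at this position because 18000 nM lies within scatter of compound 2. The step from compound 2 to compound 3 is expected to be a 1.5-fold lower number from compound 2 to compound 3 (0.18 log units; within the scatter), within the scatter. Compound 3 is therefore estimated at 22000 nM, in the range 8000 nM to 60000 nM.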

Compound 3, half-maximal effective concentration: 12000 nM
For compound 3 the middle estimate is 1.8-fold (0.26 log units) above the measured one; the range from low to high includes it.
By their numbers in this assay, from the lowest: compounds 3, 1 and 2 (each within the scatter of the next, the first and the last beyond it).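

At this position, on an oxygen on a saturated carbon, this assay now gives its first step beyond the scatter, with a 2.8-fold lower number from compound 2 to compound 3 (0.44 log units; beyond the scatter) ( 4-cyclohexylphenyl in place of 2-isopropylphenyl ). That step changes both the alkyl group and its placement on the aromatic ring, so the compounds shown cannot assign it to either change alone. Cyclohexyl in place of cyclohexyloxy on an aromatic carbon gives a 1.5-fold lower number from compound 1 to compound 3 (0.18 log units; within the scatter), so the two aryl groups carrying a cyclohexyl ring cannot be told apart in this assay.

Going by these compounds, whether an amine or a carboxylic acid on the aromatic ring at this position would shift the number further remains open. No measurement here bears on the reason for the size of either step.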